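Same ring swap, new core: what compound 4 should show

The source may report more compounds than this note shows. Statements on the series, on what has been measured and on what is new or still open speak of the compounds shown alone.

Compound 1 `Nc1ncn(CCC2(N)OC(=O)C(OCc3ccccc3)=C2OCc2ccccc2)c(=O)n1` gives in a functional assay on MCF7 cells (Homo sapiens) for inhibition, read by MTT assay, with a stated time of 72 h; a lower number here means a stronger inhibitor, a higher number a weaker inhibitor > 100000 nM, which is a limit of the assay.
Compound 2 `NC1(CCn2c(=O)[nH]c(=O)[nH]c2=O)OC(=O)C(OCc2ccccc2)=C1OCc1ccccc1` gives in this assay 84900 nM.
Compound 3 `O=C1O[C@H]([C@@H](O)Cn2c(=O)[nH]c(=O)[nH]c2=O)C(OCc2ccccc2)=C1OCc1ccccc1` gives in this assay > 100000 nM, which is a limit of the assay.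

The change a group of 8 heavy atoms (3 carbon, 4 nitrogen, 1 oxygen; one six-membered aromatic ring with 3 hetero atoms) in place of a group of 9 heavy atoms (3 carbon, 3 nitrogen, 3 oxygen; one six-membered aromatic ring with 3 hetero atoms), on a saturated chain carbon, two bonds along the chain from a saturated ring carbon produced an at least 1.1-fold higher number from compound 2 to compound 1 (0.07 log units; that floor lies within the scatter). Compound 3 carries a different core from compound 2, and the difference between the two cores is not broken down here. Compound 4 `Nc1ncn(C[C@H](O)[C@H]2OC(=O)C(OCc3ccccc3)=C2OCc2ccccc2)c(=O)n1` arises from compound 3 by a group of 8 heavy atoms (3 carbon, 4 nitrogen, 1 oxygen; one six-membered aromatic ring with 3 hetero atoms) in place of a group of 9 heavy atoms (3 carbon, 3 nitrogen, 3 oxygen; one six-membered aromatic ring with 3 hetero atoms), on a saturated chain carbon, two bonds along the chain from an oxygen on a saturated carbon and a saturated ring carbon, the same kind of change as from compound 2 to compound 1, though here the place lies two bonds along the chain from an oxygen on a saturated carbon and a saturated ring carbon rather than from a saturated ring carbon alone. Because compound 3 sits at the limit of > 100000 nM in this assay, at which 2 of the 3 values shown sit, and because the matching change gave an at least 1.1-fold higher number from compound 2 to compound 1 (0.07 log units; that floor lies within the scatter), compound 4 is expected to stay at that limit, a step that the limit leaves unreadable from compound 3 to compound 4. Compound 4 is estimated at 150000 nM, between 60000 nM and 400000 nM, most likely reported only as a limit.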

Compound 4, half-maximal inhibitory concentration: 73800 nM
The estimate for compound 4 lay 2.0-fold (0.31 log units) above the measured number, and the stated range covers the measured number.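

In this assay, within the data shown here, the swap of ring groups on the core of compound 3 gave an at least 1.3-fold lower number from compound 3 to compound 4 (0.13 log units; that floor lies within the scatter) and only this floor of the step can be read. Compound 3 gives > 100000 nM, which is a limit of the assay and not a number. The result shows no clear effect of the swap on either core, and it does not show whether the change carries over from one core to the other with the same size or direction: the same change on two cores in this assay, an at least 1.1-fold higher number (0.07 log units; that floor lies within the scatter) from compound 2 to compound 1 and an at least 1.3-fold lower number (0.13 log units; that floor lies within the scatter) from compound 3 to compound 4; the limit leaves it open whether they differ.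

From the compounds shown here alone, the true size of the step on each core stays open. Also open, going by these compounds, is how the same swap would behave on a core with a longer chain carrying the ring, or with a carboxylic acid in place of the amine.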